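The compounds below may be only part of what the source reports. "The series", "measured", "known", "first", "only" and "open" are said of these compounds alone.

Working notes on the series. All three measured compounds share one core and differ only in the group on the amine nitrogen in a ring. In a functional assay on HeLa cells (Homo sapiens) for antiproliferative activity, read by MTT assay, with a stated time of 48 h (on this read-out lower numbers stand for stronger inhibition and higher numbers for weaker inhibition), compound 1 `COc1ccc(-c2cn3cc(C4=CCN(S(=O)(=O)CCc5ccccc5)CC4)ccc3n2)cc1OC` gives 8980 nM as its number. Compound 2 `COc1ccc(-c2cn3cc(C4=CCN(C(=O)c5ccccc5C(F)(F)F)CC4)ccc3n2)cc1OC` gives 7950 nM in this assay, and compound 3 `COc1ccc(-c2cn3cc(C4=CCN(C(=O)C5CCCCC5)CC4)ccc3n2)cc1OC` gives 8060 nM there. The numbers sit close together: a 1.1-fold lower number from compound 1 to compound 2 (0.05 log units; within the scatter), a 1.1-fold lower number from compound 1 to compound 3 (0.05 log units; within the scatter) and a 1.0-fold higher number from compound 2 to compound 3 (0.01 log units; within the scatter) are all flat. Compound 3 thus stands second highest of the three, with every gap within the scatter.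

Compound 4 `COc1ccc(-c2cn3cc(C4=CCN(C(=O)c5ccc(Cl)cc5)CC4)ccc3n2)cc1OC` differs from compound 3 by 4-chlorophenyl in place of cyclohexyl on a carbonyl carbon in words. The step that bears on this is a 1.0-fold higher number from compound 2 to compound 3 (0.01 log units; within the scatter), which also exchanged the group on the carbonyl carbon and moved nothing beyond the scatter. The wider exchange of the whole group on the amine nitrogen in a ring, a 1.1-fold lower number from compound 1 to compound 3 (0.05 log units; within the scatter), was likewise flat. Within the data shown here, no step in this set leaves the scatter, so for compound 4 no change beyond the scatter is expected, that is a 1.0-fold lower number from compound 3 to compound 4 (0.00 log units; within the scatter) in this assay as the expected step. Compound 4 is estimated at 8000 nM, with an expected range of 4000 nM to 16000 nM in this assay.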

Compound 4, half-maximal inhibitory concentration: 12200 nM
Estimate against measurement, compound 4: 1.5-fold (0.18 log units) below; the measured number falls inside the stated range.
By their numbers in this assay, from the lowest: compounds 2, 3, 1 and 4 (each within the scatter of the next).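

The aromatic 4-chlorophenyl on the carbonyl carbon, in place of the non-aromatic cyclohexyl, leaves the number flat in this assay (a 1.5-fold higher number from compound 3 to compound 4 (0.18 log units; within the scatter)). The same holds for the exchange with 2-(trifluoromethyl)phenyl (a 1.5-fold higher number from compound 2 to compound 4 (0.19 log units; within the scatter)) and for the exchange of the whole group on the amine nitrogen in a ring (a 1.4-fold higher number from compound 1 to compound 4 (0.13 log units; within the scatter)), so a chlorine-bearing ring joins the earlier groups without any step leaving the scatter. Nothing available here accounts for this flatness.

As far as these compounds go, it remains open whether an amine, a carboxylic acid or a longer chain on this carbonyl carbon would give a step beyond the scatter. From the compounds shown here alone, it also remains open whether a change on the shared core, rather than at this position, would move the number in this assay.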